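Furan-2-yl Replaced by Methyl: Expected Cytotoxicity Shift

The compounds below may be only part of what the source reports. "The series", "measured", "known", "first", "only" and "open" are said of these compounds alone.

Compound 1, `Nc1ncnc2c1ncn2CC(O)C(=O)OCCO`, gives a limit of the test rather than a number in a functional assay on PRK cells (Oryctolagus cuniculus) for cytotoxicity; on this read-out higher numbers stand for lower toxicity in this test and lower numbers for higher toxicity in this test: > 400 ug/mL.
Compound 2, `CCCCCOC(=O)C(O)Cn1cnc2c(N)ncnc21`, gives 200 ug/mL.
Compound 3, `Nc1ncnc2c1ncn2CC(O)C(=O)OCc1ccco1`, gives 40 ug/mL.

All three share one core and differ only on a saturated chain carbon bound to an oxygen next to a carbonyl group. Of the two numbers shown, compound 3 has the lowest; its nearest neighbour is compound 2, a 5.0-fold lower number from compound 2 to compound 3 (0.70 log units; beyond the scatter). Compound 4, `CCOC(=O)C(O)Cn1cnc2c(N)ncnc21`, is not yet measured and carries methyl in place of furan-2-yl on a saturated chain carbon bound to an oxygen next to a carbonyl group. Within the data shown here, the steps that bear on it are a 5.0-fold lower number from compound 2 to compound 3 (0.70 log units; beyond the scatter) and an at least 10-fold lower number from compound 1 to compound 3 (1.00 log units; beyond the scatter), each showing a lower number when furan-2-yl enters; its removal is expected to push the number back up. The step from compound 3 to compound 4 is expected to read a 7.5-fold higher number from compound 3 to compound 4 (0.88 log units; beyond the scatter). Compound 4 is estimated at 300 ug/mL, within 100 ug/mL to 800 ug/mL.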

Compound 4, minimum cytotoxic concentration: > 400 ug/mL
Compound 4 was reported as a limit; the forecaster's own chance of this, stated with the estimate: 40%; middle value at least 1.3-fold (0.12 log units) from the limit.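

In this assay, methyl in place of furan-2-yl gives an at least 10-fold higher number from compound 3 to compound 4 (1.00 log units; beyond the scatter), so taking furan-2-yl away from this chain carbon moves the number clearly upward. Against the pentyl ester, the change gives an at least 2.0-fold higher number from compound 2 to compound 4 (0.30 log units; that floor lies within the scatter), a floor within the scatter, so it does not separate compound 4 from compound 2. The step between compound 1 and compound 4 cannot be read because both values are limits: the limit of > 400 ug/mL in this assay, at which 2 of the 4 values shown sit.

Going by these compounds, whether a phenyl ring at this place would also give a low number remains open. So does the outcome with an amine or a carboxylic acid.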